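This account rests on a few compounds, and the source may have more. Where it says the series, first, only, none or still open, it means among the compounds named here.

Working notes on the series

The shared core of compound 1 `O=C1C2CCCCN2C(=O)N1CN1CCN(c2ccccc2)CC1` carries a phenylpiperazine attached through a single-carbon link. In an assay on isolated protein for binding affinity to Adrenergic receptor alpha-1 (Rattus norvegicus), read by radioligand binding (on this read-out higher numbers stand for weaker inhibition and lower numbers for stronger inhibition), compound 1 gives > 1000 nM, which is a limit of the assay and not a number. Compound 2 `O=C1C2CCCCN2C(=O)N1CN1CCN(c2cccc(C(F)(F)F)c2)CC1` differs from compound 1 by trifluoromethyl in place of hydrogen on an aromatic carbon. In this assay compound 2 gives > 1000 nM, again a limit and not a number. The step that the two limits leave unreadable from compound 1 to compound 2 therefore cannot be sized from these two values; both sit at the limit of > 1000 nM in this assay, at which 2 of the 3 values shown sit.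

Compound 3 `O=C1C2CCCCN2C(=O)N1CCCCN1CCN(c2ccccc2)CC1` joins the same phenylpiperazine to the core through a longer chain. The difference between the cores of compound 1 and compound 3 is not broken down here. In this assay, among the compounds with values here, compound 3 gives 18.6 nM, the only real number in the set.

Compound 4 `O=C1C2CCCCN2C(=O)N1CCCCN1CCN(c2cccc(C(F)(F)F)c2)CC1` is not yet measured. Within the data shown here, it differs from compound 3 by trifluoromethyl in place of hydrogen on an aromatic carbon, the same change as the one from compound 1 to compound 2, made at the same place on the ring. Because the step that the two limits leave unreadable from compound 1 to compound 2 is unreadable from its two limits, there is no measured size of this change to carry over, and the expectation for compound 4 rests mainly on the value of compound 3 18.6 nM with a wide allowance in both directions. The estimated step is a 1.6-fold higher number from compound 3 to compound 4 (0.21 log units; within the scatter). For compound 4 in this assay the estimate is 30 nM, expected to fall between 8 nM and 120 nM.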

Compound 4, inhibition constant: 72.4 nM
Compound 4: middle estimate off by 2.4-fold (0.38 log units), on the low side, within the range that was stated.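

On the core of compound 3, trifluoromethyl in place of hydrogen on an aromatic carbon gives a 3.9-fold higher number from compound 3 to compound 4 (0.59 log units; beyond the scatter) in this assay, so this change yields a weaker reading on that core, and it does so at a measurable size. On the core of compound 1 the same change cannot be sized, because both values there are limits and not numbers: the limit of > 1000 nM in this assay, at which 2 of the 4 values shown sit. Carrying the change from one core to another therefore rests on a single readable instance, which shows its direction and size on the core of compound 3 only and does not show whether the change acts in the same direction, or to a similar size, on the core of compound 1.

The compounds shown leave open whether a methoxy group or a chlorine atom at the same place on the ring would read differently from trifluoromethyl on the core of compound 3. They also leave open how a propyl chain would read as the link to the phenylpiperazine, and whether the step seen here would hold on such a chain.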